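The compounds below may be only part of what the source reports. "The series", "measured", "known", "first", "only" and "open" are said of these compounds alone.

Measured so far:
- compound 1, `COc1cc(C(=O)NOCCCCCC(=O)NO)cc(OC)c1OC`: 6400 nM
- compound 2, `O=C(CCCCCONC(=O)c1cc(F)cc(F)c1)NO`: 14700 nM

Both compounds were tested in an assay on isolated protein for inhibition of histone deacetylase 8 (Homo sapiens); a higher number here means a weaker inhibitor, a lower number a stronger inhibitor. Compound 1 gives the lower of the two numbers, so it is the stronger inhibitor of this pair; compound 2 sits higher, and the gap between them lies beyond the usual scatter of repeated measurements.

The next compound, compound 3, `COc1cc(OC)cc(C(=O)NOCCCCCC(=O)NO)c1`, has not yet been measured in this assay. It differs from compound 1 in one place: hydrogen in place of methoxy on an aromatic carbon. Going by the values given here, no step between two measured compounds of this kind is available, so the size of this change can only be estimated. One methoxy fewer on the same ring is expected to shift the number little, if at all, and no step beyond the scatter is expected in this assay.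

For compound 3 the inhibition constant is expected to be about 8000 nM, with a likely range from 3000 nM to 20000 nM. The expected step of a 1.3-fold higher number from compound 1 to compound 3 (0.10 log units; within the scatter) is thus small.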

Compound 3, inhibition constant: 5690 nM
For compound 3 the middle estimate is 1.4-fold (0.15 log units) above the measured one, within the range that was stated.
By their numbers in this assay, from the lowest: compounds 3 and 1 (each within the scatter of the next); then compound 2.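

In this assay, hydrogen in place of methoxy on this aromatic carbon, ortho to two methoxy groups and para to a large group, gives a 1.1-fold lower number from compound 1 to compound 3 (0.05 log units; within the scatter). The two compounds therefore cannot be told apart, which shows that, with the two other methoxy groups in place, this methoxy can be removed without a step beyond the scatter. Nothing available explains this result.

This single pair says nothing about what the two remaining methoxy groups contribute, since no compound shown changes one of them alone. It also leaves open whether a different group on this same carbon, such as an amine or a carboxylic acid, would give a clear step in either direction.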